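A Chloro-to-Fluoro Swap and Cytotoxicity in HeLa Cells

The source may hold more compounds than are shown below. What is called first, only, known or untested is meant among the compounds shown, and "the series" means these compounds.

Of the compounds shown here, three built on one shared core have been measured in an ADME assay on HeLa cells (Homo sapiens) for cytotoxicity, read by MTT assay; on this read-out lower numbers stand for stronger inhibition and higher numbers for weaker inhibition. Compound 1 `COc1ccc(C[C@H]2COC(=O)[C@@H]2Cc2ccc(OCc3cn(Cc4ccc(Cl)cc4)nn3)c(OC)c2)cc1OC` gives 242000 nM in this assay, the highest of the three numbers. Compound 2 `COc1ccc(C[C@H]2COC(=O)[C@@H]2Cc2ccc(OC(=O)CCC(=O)N3CCCCC3)c(OC)c2)cc1OC` gives 128000 nM, a number that sits within the scatter of compound 1. Compound 3 `COC(=O)[C@@H](NC(=O)CCC(=O)Oc1ccc(C[C@H]2C(=O)OC[C@@H]2Cc2ccc(OC)c(OC)c2)cc1OC)C(C)C` gives 64000 nM, and the gap from compound 1 down to compound 3 lies beyond the scatter. Going by the values given here, the only measured step between compounds that differ in a single place is a 2.0-fold lower number from compound 2 to compound 3 (0.30 log units; within the scatter); it changes a group on a carbonyl carbon and stays within the scatter.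

Compound 4 `COc1ccc(C[C@H]2COC(=O)[C@@H]2Cc2ccc(OCc3cn(Cc4ccc(F)cc4)nn3)c(OC)c2)cc1OC` differs from compound 1 in one place, described as fluoro in place of chloro on an aromatic carbon. Read one bond further out, the change is 4-chlorobenzyl to 4-fluorobenzyl. Among the compounds with values here, no measured step touches that part of the molecule; the one recorded step alters a different region and was itself within the scatter. With nothing in the data pointing to a shift in either direction, the expected step is a 1.0-fold lower number from compound 1 to compound 4 (0.00 log units; within the scatter), which is not beyond the scatter. Compound 4 is therefore estimated at 240000 nM, with a range from 110000 nM to 520000 nM.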

Compound 4, half-maximal inhibitory concentration: 198000 nM
Compound 4: the middle estimate sits 1.2-fold (0.08 log units) above what was measured; the range from low to high includes it.
By their numbers in this assay, from the lowest: compounds 3, 2, 4 and 1 (each within the scatter of the next, the first and the last beyond it).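

In this assay, replacing the chlorine with fluorine gives a 1.2-fold lower number from compound 1 to compound 4 (0.09 log units; within the scatter), so this exchange of one halogen for another on the aromatic carbon does not separate the two compounds on this read-out. Going by these compounds alone, this is the first measured step at this end of the molecule, since the earlier step changed a group on a carbonyl carbon elsewhere, and it shows that going from 4-chlorobenzyl to 4-fluorobenzyl leaves compound 1 and compound 4 indistinguishable within the usual scatter of the measurement. Nothing measured here offers an explanation for how this pair behaves.

On these data alone, a single pair of halogens says little about this position as a whole, and it remains open whether an amine, a carboxylic acid or a methoxy group on the same aromatic carbon would produce a step beyond the scatter. Also open, as far as these compounds go, is what would happen with plain hydrogen there, which would show whether having any halogen at this position matters to the number at all.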